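A few compounds are considered here, and "the series" means these few. Any claim that something is new, unique, unknown or untested is made for them only; others in the source may bear on it.

Measured so far in an assay on isolated protein for binding affinity to 5-hydroxytryptamine receptor 6 (Homo sapiens); on this read-out higher numbers stand for weaker inhibition and lower numbers for stronger inhibition:
compound 1, `Cc1cccc(-c2n[nH]cc2N2CCCNCC2)c1`, 636 nM
compound 2, `Cc1ccc(-c2n[nH]cc2N2CCCNCC2)cc1`, 1320 nM
compound 3, `COc1cccc(-c2n[nH]cc2N2CCCNCC2)c1`, for which this assay reports only a limit, > 10000 nM

Compound 2 stands highest of the two numbers given. The nearest is compound 1, whose number is lower, and the gap between the two lies beyond the scatter. Compound 3 gives no number but sits at the limit, (the limit of > 10000 nM in this assay, at which 1 of the 3 values shown sits).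

Compound 4, `COc1ccc(-c2n[nH]cc2N2CCCNCC2)cc1`, is not yet measured. It differs from compound 2 in one place: methoxy in place of methyl on an aromatic carbon. For the measured compounds named here, one measured step bears on this change: the same swap of methoxy for methyl on an aromatic carbon of compound 1 gave an at least 15-fold higher number from compound 1 to compound 3 (1.19 log units; beyond the scatter), a large step toward weaker binding that ran into the limit. Going by the values given here, in compound 4 the swap sits at a different aromatic carbon of the same ring, so a full carry-over is not certain, but with only this step to go on, a large rise in the number from compound 2 is expected in this assay, quite possibly reaching the limit once more.

For compound 4 the estimate is 12000 nM, with a range from 3000 nM to 50000 nM. The step this estimate means is a 9.1-fold higher number from compound 2 to compound 4 (0.96 log units; beyond the scatter).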

Compound 4, inhibition constant: > 10000 nM
Compound 4 gave a limit, no number; the forecaster's own chance of this, stated with the estimate: 60%; the middle value lies beyond the limit too.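

In this assay, methoxy in place of methyl, here para to a large group, gives an at least 7.5-fold higher number from compound 2 to compound 4 (0.87 log units; beyond the scatter), so the loss seen with compound 3 is not confined to a single carbon of the aromatic ring. The swap now has two readings in the same direction, on two placements of the methyl group: the same change on two cores in this assay, an at least 15-fold higher number (1.19 log units; beyond the scatter) from compound 1 to compound 3 and an at least 7.5-fold higher number (0.87 log units; beyond the scatter) from compound 2 to compound 4; the limit leaves it open whether they differ. Compound 3 and compound 4 both stand at a limit and not at a number, so the two methoxy compounds cannot be ordered against each other: the limit of > 10000 nM in this assay, at which 2 of the 4 values shown sit.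

Still open, on these data alone, is whether the loss goes with the oxygen of the methoxy group or simply with a larger group on that carbon; an ethyl group or a chlorine at the same place would separate the two readings. Also open, as far as these compounds go, are the true size of the loss for either methoxy compound and whether the place on the ring changes it.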